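The source may report more compounds than this note shows. Statements on the series, on what has been measured and on what is new or still open speak of the compounds shown alone.

In a functional assay on A549 cells (Homo sapiens) for inhibition, read by sulforhodamine B assay, with a stated time of 72 h (on this read-out higher numbers stand for weaker inhibition and lower numbers for stronger inhibition), compound 1 `CC1CN(C(=O)c2c(N)sc(-c3ccc(Cl)cc3)c2-c2ccc(Cl)cc2)CCN1` gives 4930 nM and compound 2 `CCOC(=O)Nc1sc(-c2ccc(Cl)cc2)c(-c2ccc(Cl)cc2)c1C(=O)NC1CC1` gives 39800 nM while compound 3 `Nc1sc(-c2ccc(Cl)cc2)c(-c2ccc(Cl)cc2)c1C(=O)NC1CCC(O)CC1` gives 250 nM as the lowest number of the three, so it inhibits most strongly. Compound 4 `COc1ccc(CNC(=O)c2c(N)sc(-c3ccc(Cl)cc3)c2-c2ccc(Cl)cc2)cc1` keeps the shared core but changes one group: 4-methoxybenzyl in place of 4-hydroxycyclohexyl on an amide-type nitrogen with 4-methoxybenzyl in place of 4-hydroxycyclohexyl on an amide-type nitrogen. Going by the values given here, the one measured step at this place, a 20-fold lower number from compound 1 to compound 3 (1.29 log units; beyond the scatter) in size, was large, so a change here can move the number far. Among the compounds with values here, no measured compound carries 4-methoxybenzyl, and compound 3 sits lowest at 250 nM so a rise is expected. The expected step is a 6.0-fold higher number from compound 3 to compound 4 (0.78 log units; beyond the scatter) by this estimate, toward weaker inhibition in this assay on this reasoning. Compound 4 is estimated at 1500 nM with an expected range from 300 nM to 8000 nM for repeated measurements.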

Compound 4, half-maximal inhibitory concentration: 18200 nM
Compound 4: the middle estimate sits 12-fold (1.08 log units) below what was measured; the measured number lies above the stated range.
By their numbers in this assay, from the lowest: compound 3; then compound 1; then compound 4; then compound 2.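

In this assay, the amide-type nitrogen proves sensitive to which group it carries: 4-methoxybenzyl in place of 4-hydroxycyclohexyl gives a 73-fold higher number from compound 3 to compound 4 (1.86 log units; beyond the scatter). The strong result for compound 3 therefore does not carry over to every group on this nitrogen, and the change also gives a 3.7-fold higher number from compound 1 to compound 4 (0.57 log units; beyond the scatter). No measurement shown here explains these steps. From the compounds shown here alone, whether the ring or the hydroxyl counts for more stays open. A plain cyclohexyl or a 4-hydroxybenzyl on the same nitrogen would separate the two.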